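A few compounds are considered here, and "the series" means these few. Any claim that something is new, unique, unknown or untested is made for them only; others in the source may bear on it.

Compound 3 `COc1cc(Cl)cc(-c2nn(-c3cccc(NC(=O)Nc4ccc(Cl)c(C(F)(F)F)c4)c3)cc2-c2ccncc2)c1` holds the lowest of the three numbers recorded so far: in a functional assay on U-251 cells (Homo sapiens) for inhibition, read by sulforhodamine B assay, with a stated time of 48 h (a higher number here means a weaker inhibitor, a lower number a stronger inhibitor), compound 3 gives 730 nM. Compound 2 `O=C(Nc1cccc(-n2cc(-c3ccncc3)c(-c3cc(O)cc(Cl)c3)n2)c1)Nc1ccc(Cl)c(Cl)c1` stands nearest, and in this assay compound 2 gives 1440 nM, a gap within the scatter. Compound 1 `O=C(Nc1cccc(-n2cc(-c3ccncc3)c(-c3cc(O)cc(Cl)c3)n2)c1)Nc1ccc(Cl)c(C(F)(F)F)c1` lies furthest away; in this assay compound 1 gives 1720 nM. The step of a 2.4-fold lower number from compound 1 to compound 3 (0.37 log units; beyond the scatter) was modest yet beyond the scatter. Compound 4 `COc1cc(Cl)cc(-c2nn(-c3cccc(NC(=O)Nc4ccc(Cl)c(Cl)c4)c3)cc2-c2ccncc2)c1` differs from compound 3 by chloro in place of trifluoromethyl on an aromatic carbon. The same change has already been seen once: a 1.2-fold lower number from compound 1 to compound 2 (0.08 log units; within the scatter), which stayed within the scatter. On that basis no step beyond the scatter is expected in this assay, and the estimated step is a 1.2-fold lower number from compound 3 to compound 4 (0.07 log units; within the scatter). Compound 4 is therefore expected to give about 620 nM, within a range from 300 nM to 1400 nM.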

Compound 4, half-maximal inhibitory concentration: 1700 nM
Beside the measured number, compound 4's estimate is 2.7-fold (0.44 log units) below it; the whole stated range lies below it.
By their numbers in this assay, from the lowest: compounds 3, 2, 4 and 1 (each within the scatter of the next, the first and the last beyond it).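

In this assay, chloro in place of trifluoromethyl does not behave as it did on the earlier core: with methyl on the oxygen, the change gives a 2.3-fold higher number from compound 3 to compound 4 (0.37 log units; beyond the scatter), so its outcome at this position depends on the core that carries it: the same change on two cores in this assay, a 1.2-fold lower number (0.08 log units; within the scatter) from compound 1 to compound 2 and a 2.3-fold higher number (0.37 log units; beyond the scatter) from compound 3 to compound 4, 2.8-fold (0.44 log units) apart, beyond the scatter of two such steps With the 3,4-dichlorophenyl group in place, methyl in place of hydrogen on the oxygen gives a 1.2-fold higher number from compound 2 to compound 4 (0.07 log units; within the scatter), so the step seen with trifluoromethyl does not carry over: the same change on two cores in this assay, a 2.4-fold lower number (0.37 log units; beyond the scatter) from compound 1 to compound 3 and a 1.2-fold higher number (0.07 log units; within the scatter) from compound 2 to compound 4, 2.8-fold (0.44 log units) apart, beyond the scatter of two such steps The compounds shown leave open whether a bromo or a nitrile on this aromatic carbon would follow chloro or trifluoromethyl. They also leave open how an ethyl on the oxygen would fare with either group.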